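This account rests on a few compounds, and the source may have more. Where it says the series, first, only, none or still open, it means among the compounds named here.

Measured so far:
- compound 1 `COc1cc(-c2nnc(SCc3ccccc3Cl)n2N2C(=O)c3ccccc3C2=O)cc(OC)c1OC`; in a functional assay on MKN-45 cells (Homo sapiens) for cytotoxicity, read by MTT assay, with a stated time of 48 h (a lower number here means a stronger inhibitor, a higher number a weaker inhibitor), compound 1 gives only a limit, > 200000 nM.
- compound 2 `COc1ccc(C(=O)CSc2nnc(-c3cc(OC)c(OC)c(OC)c3)n2N2C(=O)c3ccccc3C2=O)cc1`; in this assay compound 2 gives 37200 nM.

For the measured compounds named here, compound 2 therefore holds the only actual number in this assay; the other value is a limit, not a number. The step from the one to the other is an at least 5.3-fold lower number from compound 1 to compound 2 (0.73 log units; beyond the scatter), and the lower bound of that step rests on (the limit of > 200000 nM in this assay, at which 1 of the 2 values shown sits).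

Compound 3 `COc1cc(-c2nnc(SCC(=O)c3ccc(F)cc3)n2N2C(=O)c3ccccc3C2=O)cc(OC)c1OC` is not yet measured in this assay. It differs from compound 2 by fluoro in place of methoxy on an aromatic carbon. Going by the values given here, the single measured step, an at least 5.3-fold lower number from compound 1 to compound 2 (0.73 log units; beyond the scatter), exchanges the whole group on the saturated chain carbon bound to sulfur and leaves the (4-methoxyphenyl)carbonyl itself untouched; no measured pair varies a substituent on that aromatic ring. Among the compounds with values here, there is thus no direct precedent for a methoxy-to-fluoro exchange at that position, and the change is expected to give no step beyond the scatter, a 1.1-fold higher number from compound 2 to compound 3 (0.03 log units; within the scatter). Compound 3 is estimated at 40000 nM, with a range of 15000 nM to 110000 nM.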

Compound 3, half-maximal inhibitory concentration: 126000 nM
Beside the measured number, compound 3's estimate is 3.2-fold (0.50 log units) below it, and the stated range ends below it.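

In this assay, for the compounds shown here, the aromatic ring of the (4-methoxyphenyl)carbonyl group is varied on its own for the first time, and fluoro in place of methoxy, para to a large group, gives a 3.4-fold higher number from compound 2 to compound 3 (0.53 log units; beyond the scatter) in a step that is modest but beyond the scatter. The earlier at least 5.3-fold lower number from compound 1 to compound 2 (0.73 log units; beyond the scatter) therefore cannot be credited to the carbonyl-bearing group as such, since the group on that ring also moves the number, at least in this pair. With the (4-fluorophenyl)carbonyl group, the comparison with the 2-chlorophenyl group gives an at least 1.5-fold lower number from compound 1 to compound 3 (0.20 log units; that floor lies within the scatter) and so does not establish a gain over compound 1, whose value is only a limit, and the floor of this step rests on that limit: the limit of > 200000 nM in this assay, at which 1 of the 3 values shown sits.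

From the compounds shown here alone, whether methoxy is special at this place or fluoro is simply poor remains open, and a hydroxy group, a dimethylamino group or a longer alkoxy chain on the same ring would separate the two readings. The compounds shown also leave open whether the same exchange would give a step of similar size on a side chain without the carbonyl, and no cause for the step can be read from them.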